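Methoxy in place of ethyl on a carbonyl carbon

This account rests on a few compounds, and the source may have more. Where it says the series, first, only, none or still open, it means among the compounds named here.

In a functional assay on MCF7 cells (Homo sapiens) for inhibition, read by radiometric assay and XTT assay (a higher number here means a weaker inhibitor, a lower number a stronger inhibitor), compound 1 `CCCCCCCC[C@@]1(C)SC(=O)C=C1OC` gives 16.4 ug/mL. Compound 2 `CCCCCCCC[C@@]1(C)SC(=O)C=C1OC(=O)CC` gives 26.8 ug/mL, and these two numbers lie within the scatter of each other, so compound 2 stands level with compound 1. Going by the values given here, the only measured step is a 1.6-fold higher number from compound 1 to compound 2 (0.21 log units; within the scatter), and it came from putting propanoyl in place of methyl on an oxygen on an unsaturated carbon.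

Compound 3 `CCCCCCCC[C@@]1(C)SC(=O)C=C1OC(=O)OC` is not yet measured. It differs from compound 2 by one swap: methoxy in place of ethyl on a carbonyl carbon. That is methoxy in place of ethyl on a carbonyl carbon. Among the compounds with values here, no measured pair tests this exact swap, so the one step above is only a loose guide, and it stayed small. In this assay the expected step is a 1.2-fold lower number from compound 2 to compound 3 (0.09 log units; within the scatter), with no move beyond the scatter anticipated. For compound 3 the estimate is 22 ug/mL, with an expected range from 11 ug/mL to 44 ug/mL.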

Compound 3, half-maximal inhibitory concentration: 21.6 ug/mL
Beside the measured number, compound 3's estimate is 1.0-fold (0.01 log units) above it; measured number inside the range.
By their numbers in this assay, from the lowest: compounds 1, 3 and 2 (each within the scatter of the next).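

In this assay, the swap on the carbonyl carbon gives a 1.2-fold lower number from compound 2 to compound 3 (0.09 log units; within the scatter), so at this place an ethyl and a methoxy cannot be told apart, even though the methoxy brings a hydrogen-bond acceptor that the ethyl lacks. Methoxycarbonyl in place of methyl on the oxygen gives a 1.3-fold higher number from compound 1 to compound 3 (0.12 log units; within the scatter), so a second carbonyl group on that oxygen also stands level with the plain methyl of compound 1. No measurement here speaks to why these three compounds sit so close.

With every step inside the scatter, the shared core has so far tolerated each of these groups without a readable change. Still open, on these data alone, is whether an amine, a carboxylic acid or a longer chain on this carbonyl carbon would move the number beyond the scatter.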